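Amino on the pyridine: what the microsome data suggest

The compounds below may be only part of what the source reports. "The series", "measured", "known", "first", "only" and "open" are said of these compounds alone.

Compound 1 `Cc1csc(-c2cc(NC(=O)c3ccc(OCc4ccccn4)cc3)c(C)cc2C)n1` — 513 mL.min-1.g-1
Compound 2 `Cc1cc(C)c(-c2c(C)nn(C)c2C)cc1NC(=O)c1ccc(OCc2ccccn2)cc1` — 122 mL.min-1.g-1
Compound 3 `Cc1cc(C)c(-c2ccccn2)cc1NC(=O)c1ccc(OCc2ccccn2)cc1` — 209 mL.min-1.g-1

The three measured compounds share one core and differ only in the ring attached to it. In an ADME assay on microsomes from liver (Homo sapiens) for metabolic stability (a lower number here means slower removal, a higher number faster removal of the compound), compound 1 gives 513 mL.min-1.g-1, the highest number of the three. Swapping its ring for the pyrazole gives a 4.2-fold lower number from compound 1 to compound 2 (0.62 log units; beyond the scatter), and swapping it for the pyridine gives a 2.5-fold lower number from compound 1 to compound 3 (0.39 log units; beyond the scatter). Between the pyrazole and the pyridine the change is a 1.7-fold higher number from compound 2 to compound 3 (0.23 log units; within the scatter), so compound 2 and compound 3 cannot be told apart on this assay. Compound 3 thus stands at 209 mL.min-1.g-1, second highest of the three, clearly apart from compound 1 but not from compound 2.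

Compound 4 `Cc1cc(C)c(-c2cccc(N)n2)cc1NC(=O)c1ccc(OCc2ccccn2)cc1` keeps the pyridine of compound 3 and adds one group: amino in place of hydrogen on an aromatic carbon. Among the compounds with values here, none of the measured steps bears directly on this change; each of them exchanges the whole ring, and none adds or removes a group on it. Within the data shown here, the data therefore give no direction for this step. The number for compound 4 is expected to stay close to that of compound 3, with a step of a 1.2-fold lower number from compound 3 to compound 4 (0.06 log units; within the scatter) that is within the scatter. The estimate for compound 4 is 180 mL.min-1.g-1, with a range from 80 mL.min-1.g-1 to 400 mL.min-1.g-1.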

Compound 4, intrinsic clearance in microsomes: 88 mL.min-1.g-1
Beside the measured number, compound 4's estimate is 2.0-fold (0.31 log units) above it, within the range that was stated.
By their numbers in this assay, from the lowest: compounds 4, 2 and 3 (each within the scatter of the next, the first and the last beyond it); then compound 1.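

In this assay, within the data shown here, the amino group, placed next to the ring nitrogen of the pyridine, gives a 2.4-fold lower number from compound 3 to compound 4 (0.38 log units; beyond the scatter) and so lifts the pyridine series clear of the scatter; this is the first measured step that adds a single group to the ring instead of exchanging the whole ring. With the amino group in place, the 6-aminopyridin-2-yl ring stands well apart from the 4-methyl-1,3-thiazol-2-yl ring, at a 5.8-fold lower number from compound 1 to compound 4 (0.77 log units; beyond the scatter) on the same read-out, whereas against the 1,3,5-trimethyl-1H-pyrazol-4-yl ring the figure is a 1.4-fold lower number from compound 2 to compound 4 (0.14 log units; within the scatter) and the two rings cannot be told apart. Nothing measured here goes beyond the numbers to say what lies behind this step.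

Still open, as far as these compounds go, is whether a methyl, a methoxy or a dimethylamino group in the same place would give a step of similar size, which would show how much depends on the amino group itself. A single pair also cannot show whether an amino group would act in the same way on the thiazole ring or on a different core.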